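A Further Methoxy Group on the Side-Chain Ring

A few compounds are considered here, and "the series" means these few. Any claim that something is new, unique, unknown or untested is made for them only; others in the source may bear on it.

Compound 1 `Nc1cc(N)c2nc(-c3ccccc3)c(NCc3ccc(Cl)c(Cl)c3)nc2c1` and compound 2 `COc1ccc(CNc2nc3cc(N)cc(N)c3nc2-c2ccccc2)cc1OC` share a core and differ only in the ring attached to the chain carbon bound to an aromatic nitrogen. In a functional assay on A549 cells (Homo sapiens) for inhibition, read by sulforhodamine B assay, with a stated time of 48 h (on this read-out higher numbers stand for weaker inhibition of growth and lower numbers for stronger inhibition of growth), compound 1 gives 27500 nM, and compound 2 gives 50100 nM. Of the two numbers, compound 2's is the larger, yet the step of a 1.8-fold higher number from compound 1 to compound 2 (0.26 log units; within the scatter) lies within the scatter, so the two compounds cannot be told apart. Compound 3 `COc1cc(CNc2nc3cc(N)cc(N)c3nc2-c2ccccc2)cc(OC)c1OC` has not been measured; it differs from compound 2 by methoxy in place of hydrogen on an aromatic carbon, a methoxy in place of hydrogen on an aromatic carbon. Within the data shown here, the one measured step exchanges whole ring substitution patterns and offers no direct guide to an added methoxy group, so no change beyond the scatter is expected. Compound 3 is therefore estimated at 50000 nM, between 25000 nM and 100000 nM, an expected step of a 1.0-fold lower number from compound 2 to compound 3 (0.00 log units; within the scatter).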

Compound 3, concentration for total growth inhibition: 33100 nM
Compound 3: middle estimate off by 1.5-fold (0.18 log units), on the high side; low and high end bracket the measured number.
By their numbers in this assay, from the lowest: compounds 1, 3 and 2 (each within the scatter of the next).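

In this assay, methoxy in place of hydrogen on this aromatic carbon, ortho to a methoxy group and meta to a large group, gives a 1.5-fold lower number from compound 2 to compound 3 (0.18 log units; within the scatter), so compound 2 and compound 3 cannot be told apart. The earlier pair exchanged a whole ring substitution pattern, whereas this step changes one position alone. It shows that this position can carry a methoxy group without a change that this read-out can separate from the scatter. No measurement here goes beyond the growth read-out to explain this result.

As far as these compounds go, whether an amine or a carboxylic acid on this same aromatic carbon would give a number beyond the scatter remains open. So does the effect of a longer chain there, such as ethoxy.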